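Dichlorobenzyl Variant of an Inactive Pair

A few compounds are considered here, and "the series" means these few. Any claim that something is new, unique, unknown or untested is made for them only; others in the source may bear on it.

Measured so far:
Compound 1 `O=c1ccoc2cc(OCc3cn(Cc4ccccc4)nn3)ccc12` gives > 100000 nM in this assay.
Compound 2 `Cc1cccc(Cn2cc(COc3ccc4c(=O)ccoc4c3)nn2)c1` gives > 100000 nM in this assay.

Compound 1 and compound 2 share one core and differ only by a methyl in place of hydrogen on an aromatic carbon. In a functional assay on HeLa cells (Homo sapiens) for cytotoxicity, read by MTT assay, with a stated time of 48 h (on this read-out higher numbers stand for weaker inhibition and lower numbers for stronger inhibition), compound 1 gives only a limit of the assay, not a number. Compound 2 likewise gives only a limit. The step that the two limits leave unreadable from compound 1 to compound 2 therefore has no readable size, because of the limit of > 100000 nM in this assay, at which 2 of the 2 values shown sit. Compound 1 thus stands at the limit of this assay, with no numeric value to build on.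

Compound 3 `O=c1ccoc2cc(OCc3cn(Cc4ccc(Cl)cc4Cl)nn3)ccc12` is the compound still to be measured. It differs from compound 1 by 2,4-dichlorophenyl in place of phenyl on a saturated chain carbon bound to an aromatic nitrogen. Within the data shown here, no measured step touches this change; the only measured step, a step that the two limits leave unreadable from compound 1 to compound 2, sits between two limits and gives no size at all. With both measured values at the limit, nothing here suggests the change will bring the value into readable range. Compound 3 is therefore expected to remain near the limit, and a number no higher from compound 1 to compound 3 (the limit leaves the size open) is estimated as no step beyond the scatter. The estimate for compound 3 is 100000 nM, expected to fall between 30000 nM and 300000 nM.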

Compound 3, half-maximal inhibitory concentration: 80600 nM
Compound 3: the middle estimate sits 1.2-fold (0.09 log units) above what was measured, and the stated range covers the measured number.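

In this assay, among these compounds, compound 3 is the only one of the three compounds to give a number, 80600 nM, rather than a limit of the assay, so this place on the saturated chain carbon bound to an aromatic nitrogen is the first to yield a readable value. Putting 2,4-dichlorophenyl in place of phenyl gives an at least 1.2-fold lower number from compound 1 to compound 3 (0.09 log units; that floor lies within the scatter), and putting it in place of 3-methylphenyl gives an at least 1.2-fold lower number from compound 2 to compound 3 (0.09 log units; that floor lies within the scatter). Both steps are only floors, so the true size of the change stays unknown, and the data do not establish a gain beyond what repeated measurements could produce: the limit of > 100000 nM in this assay, at which 2 of the 3 values shown sit.

Going by these compounds, it remains open whether a single chlorine on the ring would give a readable number in this assay, and how much each of the two chlorine atoms contributes. On these data alone, the effect of an amine or a carboxylic acid on the same ring, or of a longer chain in place of the saturated chain carbon, also remains open.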